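Chloro in place of trifluoromethyl: working notes

The source may report more compounds than this note shows. Statements on the series, on what has been measured and on what is new or still open speak of the compounds shown alone.

Measured so far in a functional assay on the whole organism (strain Kunming) with Mus musculus as the target, in the formalin test, with a stated time of 0.5 h (a higher number here means that more compound is needed for the effect, a lower number that less compound is needed), are these:
- compound 1 `COc1cc(OC)c(OC)cc1/C=C/COC(=O)/C=C/c1ccc(OC)c(OC)c1` gives 225 umol/kg
- compound 2 `COc1cc(OC)c(OC)cc1/C=C/COC(=O)/C=C/c1ccccc1C(F)(F)F` gives 291 umol/kg

For the measured compounds named here, compound 2 stands level with compound 1, since the only measured step is a 1.3-fold higher number from compound 1 to compound 2 (0.11 log units; within the scatter) and it also bears on the next change. Compound 3 `COc1cc(OC)c(OC)cc1/C=C/COC(=O)/C=C/c1ccccc1Cl` carries chloro in place of trifluoromethyl on an aromatic carbon on the same aromatic ring. Going by the values given here, with only that step to go on, no step beyond the scatter is expected in this assay here. Compound 3 is estimated at 255 umol/kg with an expected range of 130 umol/kg to 480 umol/kg in this read-out. The estimated change is a 1.1-fold lower number from compound 2 to compound 3 (0.06 log units; within the scatter) and stays small.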

Compound 3, dose for half-maximal effect: 260 umol/kg
Compound 3: middle estimate off by 1.0-fold (0.01 log units), on the low side, within the range that was stated.
By their numbers in this assay, from the lowest: compounds 1, 3 and 2 (each within the scatter of the next).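

Chloro on this aromatic carbon in place of trifluoromethyl gives a 1.1-fold lower number from compound 2 to compound 3 (0.05 log units; within the scatter) in this assay, so replacing four heavy atoms with one leaves the number within the scatter. 2-Chlorophenyl in place of 3,4-dimethoxyphenyl is also a small step, with a 1.2-fold higher number from compound 1 to compound 3 (0.06 log units; within the scatter) on the same chain, and no substituent change shown so far moves the number beyond the scatter. No supporting data bear on why these numbers stay level.

As far as these compounds go, whether an amine or a carboxylic acid on this aromatic carbon would leave the number within the scatter remains open. The same holds for plain phenyl at this end of the chain.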